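Swapping a nitrile for chlorine on an aminopyrimidine anilide

The source may report more compounds than this note shows. Statements on the series, on what has been measured and on what is new or still open speak of the compounds shown alone.

Measured so far in an assay on Sf9 cells for inhibition of 1-acyl-sn-glycerol-3-phosphate acyltransferase beta (Homo sapiens); on this read-out lower numbers stand for stronger inhibition and higher numbers for weaker inhibition:
- compound 1, `CCOc1ccc(Br)cc1-c1cc(Nc2ccc(C#N)cc2)nc(N)n1`: 17 nM
- compound 2, `Cc1ccc(F)cc1-c1cc(Nc2ccc(Cl)cc2)nc(N)n1`: 150 nM
- compound 3, `Cc1ccc(Cl)cc1-c1cc(Nc2cccc(Br)c2)nc(N)n1`: 610 nM

Compound 1 gives the lowest number of the three in this assay. Compound 2 sits at a higher number, beyond the scatter, and compound 3 at a still higher number, also beyond the scatter. Compound 1 is thus the most potent of this small set.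

Compound 4, `CCOc1ccc(Br)cc1-c1cc(Nc2ccc(Cl)cc2)nc(N)n1`, has not yet been measured. It keeps the core of compound 1 unchanged and differs only at the far end of the anilide: chloro in place of cyano on an aromatic carbon. The two neighbouring compounds that already carry a halogen on that ring, compound 2 and compound 3, have a different core and so do not define this step directly; they only show that halogenated anilides of this type can sit well above compound 1 in this assay.

For compound 4 the step from compound 1 is expected to be a 2.4-fold higher number from compound 1 to compound 4 (0.37 log units; beyond the scatter), toward a somewhat higher number, though it may not exceed the scatter. Compound 4 is estimated at 40 nM, within 12 nM to 130 nM.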

Compound 4, half-maximal inhibitory concentration: 16 nM
The estimate for compound 4 lay 2.5-fold (0.40 log units) above the measured number; measured number inside the range.
By their numbers in this assay, from the lowest: compounds 4 and 1 (each within the scatter of the next); then compound 2; then compound 3.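

In this assay, putting chloro in place of cyano on an aromatic carbon, para to a large group, gives a 1.1-fold lower number from compound 1 to compound 4 (0.03 log units; within the scatter). With the core of compound 1 held fixed, this read-out therefore does not separate the two groups at this position, even though the leaving cyano carries a hydrogen-bond acceptor and the entering chloro carries none. Compound 2 and compound 3 differ from this pair in more than one place and could not show this, and no measurement here bears on why the two groups read alike.

From the compounds shown here alone, it remains open whether this position would read the same with groups of another kind, such as an amine, a carboxylic acid or a methoxy group, as one pair says nothing about them. It is also open whether the change from 4-cyanophenyl to 4-chlorophenyl would give a similar step on a different core, such as that of compound 2, as no pair among the compounds shown tests it.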